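The source may hold more compounds than are shown below. What is called first, only, known or untested is meant among the compounds shown, and "the series" means these compounds.

Of the compounds shown here, three built on one shared core have been tested in an assay on isolated protein for inhibition of Apoptosis regulator Bcl-2 (Homo sapiens), read by fluorescence polarization, with stated times of 5 min and 10 min; a lower number here means a stronger inhibitor, a higher number a weaker inhibitor. Compound 1 `CON(C)C(=O)[C@H]1CC2=C(CCCC2(C)C)C[C@@H]1c1ccccc1` returns only a limit, > 23000 nM. Compound 3 `CC(C)=CCCC1=CC[C@H](C(N)=O)[C@@H](c2ccccc2)C1` likewise returns only a limit, > 23000 nM. Compound 2 `COC(=O)CCNC(=O)[C@@H]1CC=C(CCC=C(C)C)C[C@H]1c1ccccc1` also gives no number but a limit, > 23000 nM. Every measured value therefore sits at the same point, (the limit of > 23000 nM in this assay, at which 3 of the 3 values shown sit), so compound 2 has no rank within this set. Compound 4 `CC(C)=CCCC1=CC[C@@H](C(=O)Nc2ccc(O)cc2)[C@H](c2ccccc2)C1` differs from compound 2 in one place: 4-hydroxyphenyl in place of 2-(methoxycarbonyl)ethyl on an amide-type nitrogen. Among the measured compounds shown here, no measured step exists to guide the size of this change, so either a modest gain or no move beyond the scatter is expected. For compound 4 the expected value is 15000 nM, within a range from 3000 nM to 60000 nM. The expected step is an at least 1.5-fold lower number from compound 2 to compound 4 (0.18 log units; that floor lies within the scatter).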

Compound 4, inhibition constant: > 23000 nM
Compound 4 gave a limit, no number (the forecaster's own chance of this, stated with the estimate: 60%); at least 1.5-fold (0.18 log units) between middle value and limit.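

No step can be read from compound 2 to compound 4, since each gives only a limit, not a number: the limit of > 23000 nM in this assay, at which 4 of the 4 values shown sit.

The compounds shown leave open which change to the shared core or its amide substituent, if any, would yield a measurable number.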